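The source may report more compounds than this note shows. Statements on the series, on what has been measured and on what is new or still open speak of the compounds shown alone.

Compound 1 `C=C(CC[C@H]1[C@@H](C)CCCC1(C)C)C(O)Cc1c(O)cc(C)c(C=O)c1O` is the anchor of this small set. In a functional assay on EC17 cells (Homo sapiens) for inhibition, with a stated time of 24 h (on this read-out lower numbers stand for stronger inhibition and higher numbers for weaker inhibition), compound 1 gives 1980 nM, the lowest of the three numbers recorded. Compound 3 `Cc1cc(O)c(CC(O)C(C)CC[C@H]2[C@@H](C)CCCC2(C)C)c(O)c1C=O` gives 2120 nM in this assay, and the two values lie within the scatter of each other. For the measured compounds named here, compound 2 `C=C(CC[C@H]1[C@@H](C)CCCC1(C)C)C(O)Cc1c(OC)cc(C)c(C=O)c1O` gives 4570 nM in this assay; the only single-point step that has been measured, a 2.3-fold higher number from compound 1 to compound 2 (0.36 log units; beyond the scatter), follows a methyl in place of hydrogen on an oxygen on an aromatic ring.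

Compound 4 `C=C(CC/C=C(\C)CCC=C(C)C)C(O)Cc1c(O)cc(C)c(C=O)c1O` has not yet been measured. It differs from compound 1 in one place: 2,6-dimethylhepta-1,5-dien-1-yl in place of 2,2,6-trimethylcyclohexyl on a saturated chain carbon, two bonds along the chain from a double-bonded chain carbon. Going by the values given here, none of the measured steps touches this part of the molecule; the methylation step concerns the phenolic oxygen, and compounds 1 and 3, which differ elsewhere on the chain, show no separation beyond the scatter. No measured change on the core or chain has therefore moved this assay strongly, and the expectation is a step of a 1.3-fold higher number from compound 1 to compound 4 (0.10 log units; within the scatter), which is not beyond the scatter. On that basis compound 4 is estimated to give 2500 nM in this assay, with a plausible range from 800 nM to 8000 nM.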

Compound 4, half-maximal inhibitory concentration: 7530 nM
For compound 4 the middle estimate is 3.0-fold (0.48 log units) below the measured one, within the range that was stated.
By their numbers in this assay, from the lowest: compounds 1 and 3 (each within the scatter of the next); then compounds 2 and 4 (each within the scatter of the next).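

In this assay, for the compounds shown here, the swap of 2,2,6-trimethylcyclohexyl for 2,6-dimethylhepta-1,5-dien-1-yl gives the first measured step at this end of the chain (a 3.8-fold higher number from compound 1 to compound 4 (0.58 log units; beyond the scatter)), showing that the position on a saturated chain carbon, two bonds along the chain from a double-bonded chain carbon, is sensitive to the group it carries. The two groups have the same heavy-atom count, all carbon, and neither has a hydrogen-bond donor or acceptor; they differ in that the leaving group has a ring and two defined stereocentres, whereas the entering group has no ring and two double bonds outside aromatic rings. Nothing in the available data gives a reason for this step.

The compounds shown leave open whether the loss of the ring or the presence of the double bonds accounts for the step, a question that a saturated open chain such as 2,6-dimethylheptyl at the same place could help to settle. They also leave open how an unsubstituted cyclohexyl or a phenyl group would read in this position.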